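The source may hold more compounds than are shown below. What is called first, only, known or untested is meant among the compounds shown, and "the series" means these compounds.

Measured so far:
compound 1 `OC[C@@]1(c2cccc(F)c2)NC[C@@H](O)[C@@H]1O` gives 0%
compound 2 `OC[C@@]1(c2ccc(O)cc2)NC[C@@H](O)[C@@H]1O` gives 2.2%

Of the compounds shown here, two have been measured in an assay on isolated protein for inhibition of alpha-mannosidase (Canavalia ensiformis), tested at 1000 uM; on this read-out lower numbers stand for less inhibition and higher numbers for more inhibition at the one concentration tested (going by the name of the read-out). Compound 1 `OC[C@@]1(c2cccc(F)c2)NC[C@@H](O)[C@@H]1O` gives 0% in this assay. Compound 2 `OC[C@@]1(c2ccc(O)cc2)NC[C@@H](O)[C@@H]1O` gives 2.2% in this assay, which is the higher of the two numbers, though its gap to compound 1 is within the scatter, so the two read as alike. Compound 3 `OC[C@@]1(c2ccccc2)NC[C@@H](O)[C@@H]1O` has not yet been measured in this assay. The change from compound 2 to compound 3 is hydrogen in place of hydroxy on an aromatic carbon. Among the compounds with values here, no step between measured compounds has been worked out, so there is no measured change to lean on. Since compound 1 gives 0% and compound 2 gives 2.2%, both small numbers, the expected step is a number 0.7 percentage points lower from compound 2 to compound 3 (within the scatter), none beyond the scatter. Compound 3 is therefore estimated at 1.5%, within 0% to 10%.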

Compound 3, a percentage reported as inhibition, at one concentration (the size of the read-out at that concentration, not a potency): 0%
Estimate against measurement, compound 3: 1.5 percentage points above; the measured number falls inside the stated range.
By their numbers in this assay, from the lowest: compounds 1, 3 and 2 (each within the scatter of the next).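

Read in this assay, hydrogen in place of hydroxy on the aromatic carbon para to a group of 9 heavy atoms gives a number 2.2 percentage points lower from compound 2 to compound 3 (within the scatter), so this change has no readable effect at this position. Hydrogen in place of fluoro gives no change at the digits printed from compound 1 to compound 3 (within the scatter), so neither of the two groups sets its compound apart from compound 3, which carries only hydrogen on the aromatic ring and gives 0%. No measured evidence bears on these results.

As far as these compounds go, whether an amine or a carboxylic acid on the aromatic ring would move the number beyond the scatter remains open. So does whether a longer chain there would do so, as the compounds shown offer no step beyond the scatter against which to judge any other group.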